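Moving the chlorine on the sulfonyl-bound phenyl ring

The compounds below may be only part of what the source reports. "The series", "measured", "known", "first", "only" and "open" are said of these compounds alone.

Compound 1, `CN1CCC(n2cc(S(=O)(=O)c3ccc(F)cc3)c3cccnc32)C1`: 5 nM
Compound 2, `CN1CCC(n2cc(S(=O)(=O)c3ccccc3Cl)c3cccnc32)C1`: 2.2 nM

Compound 2 stands with the lowest of the two numbers measured in an assay on HeLa cells for displacement of a labelled ligand from 5-hydroxytryptamine receptor 6 (Homo sapiens); a lower number here means a stronger inhibitor, a higher number a weaker inhibitor; its nearest neighbour is compound 1, and the step of a 2.3-fold lower number from compound 1 to compound 2 (0.36 log units; beyond the scatter) lies beyond the scatter. Compound 3, `CN1CCC(n2cc(S(=O)(=O)c3cccc(Cl)c3)c3cccnc32)C1`, has not been measured. It differs from compound 2 by 3-chlorophenyl in place of 2-chlorophenyl on a sulfonyl sulfur, the two sharing the same atoms joined differently. For the measured compounds named here, only the step from compound 1 to compound 2 touches this part of the molecule, and it changed both the halogen and its position at once, so it gives no direct reading on moving a chlorine from one ring position to another. Compound 3 is therefore expected to stay close to compound 2, with a step of a 1.6-fold higher number from compound 2 to compound 3 (0.20 log units; within the scatter) that need not exceed the scatter. Compound 3 is estimated at 3.5 nM, within 1.2 nM to 10 nM.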

Compound 3, inhibition constant: 1.5 nM
Compound 3: the middle estimate sits 2.3-fold (0.37 log units) above what was measured; the measured number falls inside the stated range.
By their numbers in this assay, from the lowest: compounds 3 and 2 (each within the scatter of the next); then compound 1.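

In this assay, for the compounds shown here, the chlorine alone changes place for the first time, and the result is a 1.5-fold lower number from compound 2 to compound 3 (0.17 log units; within the scatter), so 3-chlorophenyl and 2-chlorophenyl on a sulfonyl sulfur cannot be told apart here. The 3-chlorophenyl group still gives a 3.3-fold lower number from compound 1 to compound 3 (0.52 log units; beyond the scatter), so both chlorophenyl compounds, not only compound 2, stand apart from the 4-fluorophenyl compound 1. No evidence is at hand that bears on why the numbers fall this way.

Going by these compounds, whether the halogen or its ring position carries the gap to compound 1 stays open, and a 4-chlorophenyl or a 3-fluorophenyl group would separate the two. Also open, on these data alone, is how this position responds to a phenyl ring carrying an amine or a carboxylic acid in place of the halogen.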